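This account rests on a few compounds, and the source may have more. Where it says the series, first, only, none or still open, it means among the compounds named here.

In a functional assay on B16 cells (Mus musculus) for antiproliferative activity, read by MTT assay, with a stated time of 24 h (a higher number here means a weaker inhibitor, a lower number a stronger inhibitor), compound 1 (`COc1cc(OC)c(-c2coc3cc(OCc4ccccc4C)ccc3c2=O)cc1OC`) gives 2150 nM and compound 2 (`COc1cc(OC)c(-c2coc3cc(OCc4ccc(Cl)cc4)ccc3c2=O)cc1OC`) gives 2400 nM while compound 3 (`COc1cc(OC)c(-c2coc3cc(OCc4cccc(Cl)c4)ccc3c2=O)cc1OC`) gives 2280 nM on the same shared core. These three values lie within the scatter of one another, so compound 3 holds no distinct rank among them. Compound 4 (`COc1cc(OC)c(-c2coc3cc(OCc4cccc(C(F)(F)F)c4)ccc3c2=O)cc1OC`) has no number yet. It differs from compound 3 by trifluoromethyl in place of chloro on an aromatic carbon in the form of trifluoromethyl in place of chloro on an aromatic carbon, meta to a large group, so that 3-chlorobenzyl becomes 3-(trifluoromethyl)benzyl.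

For the measured compounds named here, three measured steps bear on this change: a 1.1-fold higher number from compound 1 to compound 3 (0.03 log units; within the scatter) and a 1.1-fold lower number from compound 2 to compound 3 (0.02 log units; within the scatter) and also a 1.1-fold higher number from compound 1 to compound 2 (0.05 log units; within the scatter) and each of them is small and within the scatter. Going by the values given here, no measured compound carries trifluoromethyl, so these steps offer only indirect guidance and the range is kept wide on both sides. No step beyond the scatter is expected in this assay for this change. The estimated step is a 1.0-fold higher number from compound 3 to compound 4 (0.00 log units; within the scatter) and it is expected to stay small. Compound 4 is estimated at 2300 nM with an expected range from 1300 nM to 4000 nM in this series.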

Compound 4, half-maximal inhibitory concentration: > 10000 nM
Compound 4: no number, only a limit; the forecaster's own chance of this, stated with the estimate: 2%; middle value at least 4.3-fold (0.63 log units) away from the limit.
By their numbers in this assay, from the lowest: compounds 1, 3 and 2 (each within the scatter of the next). At a limit, above all of these: compound 4.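

Compound 4 gives > 10000 nM in this assay, a limit of the assay and not a number: the limit of > 10000 nM in this assay, at which 1 of the 4 values shown sits. For the compounds shown here, this is the first change to reach beyond the scatter, with trifluoromethyl in place of chloro on an aromatic carbon, meta to a large group, giving an at least 4.3-fold higher number from compound 3 to compound 4 (0.64 log units; beyond the scatter). The comparisons with the other two benzyl ethers point the same way, giving an at least 4.1-fold higher number from compound 2 to compound 4 (0.61 log units; beyond the scatter) for 3-(trifluoromethyl)phenyl in place of 4-chlorophenyl and an at least 4.6-fold higher number from compound 1 to compound 4 (0.66 log units; beyond the scatter) for 3-(trifluoromethyl)phenyl in place of 2-methylphenyl, whereas the exchanges among 2-methylphenyl, 4-chlorophenyl and 3-chlorophenyl all stayed within the scatter.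

From the compounds shown here alone, with only a limit for compound 4, the true size of these steps stays open, and each is known only from one side. Also open, going by these compounds, is whether the loss belongs to trifluoromethyl alone or would also appear with another group on the same aromatic carbon, such as methyl, methoxy, a nitrile or an amine.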